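Acyl hydrazone series: from compound 1 to compound 3

The source may hold more compounds than are shown below. What is called first, only, known or untested is meant among the compounds shown, and "the series" means these compounds.

Measured in a functional assay on MDA-MB-231 cells (Homo sapiens) for antiproliferative activity, with a stated time of 4 days; on this read-out higher numbers stand for weaker inhibition and lower numbers for stronger inhibition:
- compound 1 `CCCCc1ccc2[nH]c(-c3ccc(OC)cc3)c(/C=N/NC(=O)c3ccc(OC)cc3)c2c1`: 61 nM
- compound 2 `CCCCc1ccc2[nH]c(-c3ccc(CC)cc3)c(/C=N/NC(=O)c3ccncc3)c2c1`: 80 nM

Compound 1 gives 61 nM and compound 2 gives 80 nM. These two values lie within the usual scatter of each other, so compound 1 stands level with compound 2 and holds no separate rank. For the measured compounds named here, with only two measurements, no trend can be read from the series.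

The next compound is compound 3 `CCCCc1ccc2[nH]c(-c3ccc(OC)cc3)c(/C=N/NC(=O)c3cccnc3)c2c1`. Its change from compound 1 is pyridin-3-yl in place of 4-methoxyphenyl on a carbonyl carbon. The rest of the structure stays the same.

Going by the values given here, no two measured compounds differ in one place only, so the data show no direct step for this change. Among the compounds with values here, the only guide is that compound 2, at 80 nM, stays in the same range as compound 1. A small move to a higher number in this assay is therefore expected, possibly none beyond the scatter. The expected change is a 1.5-fold higher number from compound 1 to compound 3 (0.17 log units; within the scatter). For compound 3 the estimated value is 90 nM, with an expected range from 35 nM to 250 nM.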

Compound 3, half-maximal inhibitory concentration: 35 nM
The estimate for compound 3 lay 2.6-fold (0.41 log units) above the measured number; the range from low to high includes it.
By their numbers in this assay, from the lowest: compounds 3, 1 and 2 (each within the scatter of the next, the first and the last beyond it).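

In this assay, for the compounds shown here, pyridin-3-yl in place of 4-methoxyphenyl on a carbonyl carbon gives a 1.7-fold lower number from compound 1 to compound 3 (0.24 log units; within the scatter), the first direct step at this position. The position therefore accepts a six-membered aromatic ring with a hetero atom and without the methoxy group, and the reading stays in the same range, so the 4-methoxyphenyl group is not needed here to keep this read-out. Nothing measured on these compounds speaks to why the two groups read alike.

The compounds shown leave open whether this carbonyl carbon can carry something other than a six-membered aromatic ring, such as a saturated piperidine ring, a short alkyl chain or a phenyl ring bearing a carboxylic acid. The ring on the carbonyl carbon of compound 2 also holds a nitrogen, but compound 2 differs from compound 3 in more than one place, so the effect of where that nitrogen sits in the ring remains unresolved.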